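This account rests on a few compounds, and the source may have more. Where it says the series, first, only, none or still open, it means among the compounds named here.

Of the compounds shown here, three sharing one core have been measured so far, differing only in the group on the outer benzene ring. Compound 1 `Fc1ccccc1-c1ccc2[nH]ncc2c1` carries a fluoro there and gives 3950 nM in an assay on CHO-TREX cells for antagonist activity at transient receptor potential cation channel subfamily A member 1 (Homo sapiens), read by FLIPR and calcium flux, with a stated time of 10 min; a higher number here means a weaker inhibitor, a lower number a stronger inhibitor. Compound 2 `Cc1ccccc1-c1ccc2[nH]ncc2c1` carries a methyl and gives 7810 nM in this assay; the step of a 2.0-fold higher number from compound 1 to compound 2 (0.30 log units; within the scatter) lies within the scatter. Compound 3 `CCc1ccccc1-c1ccc2[nH]ncc2c1` carries an ethyl and gives 584 nM in this assay, the lowest of the three numbers, and both of its steps are beyond the scatter: a 6.8-fold lower number from compound 1 to compound 3 (0.83 log units; beyond the scatter) and a 13-fold lower number from compound 2 to compound 3 (1.13 log units; beyond the scatter).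

Compound 4 `FC(F)(F)c1ccccc1-c1ccc2[nH]ncc2c1` is not yet measured. It differs from compound 3 in one place: trifluoromethyl in place of ethyl on an aromatic carbon. For the measured compounds named here, the steps that bear on this are the two leading into compound 3, since they show that changing the group at this position moves the number by a modest to large amount, with fluoro and methyl both giving higher numbers than ethyl. Trifluoromethyl is none of these groups, so the expected step of a 2.6-fold higher number from compound 3 to compound 4 (0.41 log units; beyond the scatter) is a moderate rise, because compound 3 at 584 nM stands well below the other two. Compound 4 is therefore estimated at 1500 nM in this assay, within a range of 400 nM to 6000 nM.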

Compound 4, half-maximal inhibitory concentration: 164 nM
Compound 4: the middle estimate sits 9.1-fold (0.96 log units) above what was measured; measured number outside the range, below it.
By their numbers in this assay, from the lowest: compound 4; then compound 3; then compounds 1 and 2 (each within the scatter of the next).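

Among the four compounds, trifluoromethyl now gives the lowest number at this place on the outer ring in this assay, and each of its steps lies beyond the scatter. The earlier compounds shown here left ethyl as the best group there, but the change to trifluoromethyl, with a 3.6-fold lower number from compound 3 to compound 4 (0.55 log units; beyond the scatter), shows that ethyl does not mark the limit of what this position can give. The other two steps show how strongly the outcome depends on the exact group: fluoro and methyl sit within the scatter of each other, yet a 24-fold lower number from compound 1 to compound 4 (1.38 log units; beyond the scatter) and a 48-fold lower number from compound 2 to compound 4 (1.68 log units; beyond the scatter), the second being the largest step in the set, so a single fluorine and a plain methyl gave no hint of what a carbon bearing three fluorines would do.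

The compounds shown leave open whether a longer chain such as propyl, a chlorine atom or a methoxy group at this place would give a still lower number in this assay. Nothing available here explains why trifluoromethyl and ethyl stand apart from fluoro and methyl.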